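A few compounds are considered here, and "the series" means these few. Any claim that something is new, unique, unknown or untested is made for them only; others in the source may bear on it.

Measured compounds:
compound 1 `NS(=O)(=O)c1ccc(N2N=C(c3ccc(OCc4ccccc4)cc3)CC2c2ccc(F)cc2)cc1` — 60000 nM
compound 2 `NS(=O)(=O)c1ccc(N2N=C(c3ccc(Oc4ccccc4)cc3)CC2c2ccccc2)cc1` — 11000 nM
compound 3 `Cc1cccc(C2CC(c3ccccc3)=NN2c2ccc(S(N)(=O)=O)cc2)c1` — 25000 nM

In an ADME assay on BHK-21 cells (Mesocricetus auratus) for cytotoxicity, read by MTT assay, with a stated time of 72 h (a higher number here means that more compound is tolerated, a lower number that less compound is tolerated), compound 1 gives 60000 nM, the highest of the three numbers and the best tolerated of the set, its gaps to both others lying beyond the usual scatter. Compound 3 gives 25000 nM and stands nearest to it. Compound 2 gives 11000 nM and stands furthest from it. Within the data shown here, no pair among the measured compounds differs in one place only, so no single structural step has a measured size to lean on.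

Compound 4 `NS(=O)(=O)c1ccc(N2N=C(c3ccc(OCc4ccccc4)cc3)CC2c2ccccc2Cl)cc1` has not yet been measured in this assay. It differs from compound 1 as 2-chlorophenyl in place of 4-fluorophenyl on a saturated ring carbon. The shared core and the other substituents are unchanged. Among the measured compounds shown here, with no comparable measured step available, the expectation is a modest change at most: compound 4 is estimated to sit somewhat below compound 1, with a 1.3-fold lower number from compound 1 to compound 4 (0.12 log units; within the scatter) expected to stay within the usual scatter. The estimate for compound 4 is 45000 nM, with a range from 20000 nM to 100000 nM.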

Compound 4, half-maximal cytotoxic concentration: 12000 nM
Estimate against measurement, compound 4: 3.8-fold (0.57 log units) above; measured number below the stated range.
By their numbers in this assay, from the lowest: compounds 2 and 4 (each within the scatter of the next); then compound 3; then compound 1.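

In this assay, among these compounds, the saturated ring carbon proves sensitive to which phenyl group it carries: 2-chlorophenyl in place of 4-fluorophenyl gives a 5.0-fold lower number from compound 1 to compound 4 (0.70 log units; beyond the scatter) and this is the first step with a measured size. Less compound is tolerated after the change, even though the two groups match in heavy-atom count and in their count of hydrogen-bond donors and acceptors. Nothing available bears on why the number falls.

As far as these compounds go, this one step changes the halogen and its place on the phenyl ring together, so the share of each stays open. Also open, from the compounds shown here alone, is how the number responds at this carbon to a phenyl ring bearing an amine or a carboxylic acid, and whether the step keeps its size with another group on the far side of the shared core.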